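Replacing Fluoro with Trifluoromethyl on a Cytotoxic Amide

This account rests on a few compounds, and the source may have more. Where it says the series, first, only, none or still open, it means among the compounds named here.

Of the compounds shown here, three sharing one core have been tested in a functional assay on PC-3 cells (Homo sapiens) for cytotoxicity, read by MTT assay, with a stated time of 72 h; on this read-out lower numbers stand for stronger inhibition and higher numbers for weaker inhibition. Compound 1 `COc1ccc(C(=O)c2cc(OC)c(OC)c(OC)c2)cc1NC(=O)/C=C/c1ccc(OC)c(OC)c1` gives 7500 nM in this assay, compound 2 `COc1ccc(/C=C/C(=O)Nc2cc(C(=O)c3cc(OC)c(OC)c(OC)c3)ccc2OC)cc1` gives 11100 nM, and compound 3 `COc1ccc(C(=O)c2cc(OC)c(OC)c(OC)c2)cc1NC(=O)/C=C/c1ccc(F)cc1` gives 3200 nM, the lowest of the three numbers. The step of a 2.3-fold lower number from compound 1 to compound 3 (0.37 log units; beyond the scatter) and the step of a 3.5-fold lower number from compound 2 to compound 3 (0.54 log units; beyond the scatter) both favour compound 3, while a 1.5-fold higher number from compound 1 to compound 2 (0.17 log units; within the scatter) stays within the scatter.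

Compound 4 `COc1ccc(C(=O)c2cc(OC)c(OC)c(OC)c2)cc1NC(=O)/C=C/c1ccc(C(F)(F)F)cc1` differs from compound 3 by a single change: trifluoromethyl in place of fluoro on an aromatic carbon. For the measured compounds named here, no measured pair shows this exact exchange. Going by the values given here, the only step that touches the same position, a 3.5-fold lower number from compound 2 to compound 3 (0.54 log units; beyond the scatter), moved by a modest amount when a methoxy left and a fluoro entered, so a change at this place can shift the number, but the direction for a trifluoromethyl cannot be read from the present data. A small step, likely within the scatter, is therefore expected for a 1.1-fold higher number from compound 3 to compound 4 (0.04 log units; within the scatter). Compound 4 is estimated at 3500 nM, with a plausible range from 1400 nM to 9000 nM.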

Compound 4, half-maximal inhibitory concentration: 3500 nM
Estimate against measurement, compound 4: no gap at the digits printed; low and high end bracket the measured number.
By their numbers in this assay, from the lowest: compounds 3 and 4 (each within the scatter of the next); then compounds 1 and 2 (each within the scatter of the next).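

In this assay, going from one heavy atom to four on this aromatic carbon gives a 1.1-fold higher number from compound 3 to compound 4 (0.04 log units; within the scatter), so here fluoro and trifluoromethyl cannot be told apart, even though the two groups differ clearly in size. Trifluoromethyl also keeps the lower number seen against the methoxy-bearing compounds, with a 3.2-fold lower number from compound 2 to compound 4 (0.50 log units; beyond the scatter) and a 2.1-fold lower number from compound 1 to compound 4 (0.33 log units; beyond the scatter), which shows that this lower number is not unique to fluoro. No measurement at hand explains why the two groups give such similar numbers.

As far as these compounds go, whether an amine, a carboxylic acid or a longer chain on this same carbon would shift the number remains open. From the compounds shown here alone, it is also open whether the exchange of fluoro for trifluoromethyl would read the same at another carbon of this aromatic ring.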